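Nitro for hydroxy on a fluorinated stilbene core

This account rests on a few compounds, and the source may have more. Where it says the series, first, only, none or still open, it means among the compounds named here.

Measured compounds:
compound 1 `COc1ccc(/C(F)=C\c2cc(OC)c(OC)c(OC)c2)cc1O`, 4700 nM
compound 2 `COc1ccc(/C(F)=C\c2cc(OC)c(OC)c(OC)c2)cc1[N+](=O)[O-]`, 329000 nM
compound 3 `COc1ccc(/C(F)=C(/F)c2cc(OC)c(OC)c(OC)c2)cc1O`, 4600 nM

In a functional assay on cells (Endothelial cell, Bos taurus) for antiproliferative activity (on this read-out lower numbers stand for stronger inhibition and higher numbers for weaker inhibition), compound 1 gives 4700 nM and compound 3 gives 4600 nM, two values within the scatter of each other. The change from compound 1 to compound 2, (nitro in place of hydroxy on an aromatic carbon), produced a 70-fold higher number from compound 1 to compound 2 (1.85 log units; beyond the scatter). Compound 4 `COc1ccc(/C(F)=C(/F)c2cc(OC)c(OC)c(OC)c2)cc1[N+](=O)[O-]` is not yet measured; it arises from compound 3 by the same change, (nitro in place of hydroxy on an aromatic carbon). The difference between the two cores, compound 1 against compound 3, is not broken down here. Since the two starting points give matching values in this assay and the change is the same, a step close to a 70-fold higher number from compound 1 to compound 2 (1.85 log units; beyond the scatter) is expected, so compound 4 is expected at a 70-fold higher number from compound 3 to compound 4 (1.84 log units; beyond the scatter). For compound 4 the estimate is therefore 320000 nM, between 100000 nM and 1000000 nM.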

Compound 4, half-maximal inhibitory concentration: 749000 nM
Beside the measured number, compound 4's estimate is 2.3-fold (0.37 log units) below it; measured number inside the range.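

In this assay, putting nitro in place of hydroxy gives a 160-fold higher number from compound 3 to compound 4 (2.21 log units; beyond the scatter), so the large loss of inhibition seen on the core of compound 1 appears again on the core of compound 3. The two steps agree as closely as repeated measurements would allow, which means the change carries over between these two cores: the same change on two cores in this assay, a 70-fold higher number (1.85 log units; beyond the scatter) from compound 1 to compound 2 and a 160-fold higher number (2.21 log units; beyond the scatter) from compound 3 to compound 4, 2.3-fold (0.37 log units) apart, within the scatter of two such steps. Among these compounds, this rests on only two pairs of compounds in a single assay, and it does not show why nitro weakens inhibition or whether the same would hold on any other core.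

The compounds shown carry only hydroxy or nitro at this place on the ring. Going by these compounds, whether an amine or a carboxylic acid there would stay close to compound 1 and compound 3, or fall away like compound 2 and compound 4, remains open.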